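This account rests on a few compounds, and the source may have more. Where it says the series, first, only, none or still open, it means among the compounds named here.

In a functional assay on Hs68 cells (Homo sapiens) for cytotoxicity (a lower number here means that less compound is tolerated, a higher number that more compound is tolerated), compound 1 `CC(C)Oc1ccccc1CNC(=O)c1ccc2cncc(Br)c2n1` gives 9 ug/mL. Compound 2 `Cc1cncc2ccc(C(=O)NCc3ccccc3OC(C)C)nc12` gives 3 ug/mL, and compound 3 `O=C(NCc1ccc(Br)cc1)c1ccc2cnccc2n1` gives 10 ug/mL, so compound 1 lies within the scatter of compound 3 and clear of compound 2. Compound 4 `CC(C)Oc1ccccc1CNC(=O)c1ccc2cnccc2n1` differs from compound 1 by hydrogen in place of bromo on an aromatic carbon. Within the data shown here, the only measured step at that carbon is a 3.0-fold lower number from compound 1 to compound 2 (0.48 log units; beyond the scatter), which is modest and beyond the scatter, but it brings in methyl rather than hydrogen. Compound 3 shares the core of compound 4 but has a different amide side chain. No step beyond the scatter is therefore expected in this assay, and no direction is favoured. The expected change is a 1.1-fold lower number from compound 1 to compound 4 (0.05 log units; within the scatter). For compound 4 the estimated value is 8 ug/mL, with a range of 3.5 ug/mL to 18 ug/mL.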

Compound 4, half-maximal cytotoxic concentration: 2.5 ug/mL
The estimate for compound 4 lay 3.2-fold (0.51 log units) above the measured number; measured number outside the range, below it.
By their numbers in this assay, from the lowest: compounds 4 and 2 (each within the scatter of the next); then compounds 1 and 3 (each within the scatter of the next).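

In this assay replacing bromo with hydrogen gives a 3.6-fold lower number from compound 1 to compound 4 (0.56 log units; beyond the scatter) while replacing methyl with hydrogen gives a 1.2-fold lower number from compound 2 to compound 4 (0.08 log units; within the scatter) so hydrogen and methyl cannot be told apart at this aromatic carbon. Among the three groups shown here, bromo alone stands apart, with more compound tolerated, and the earlier step from bromo to methyl now reads as a loss of bromo rather than a contribution from methyl. No evidence available here bears on the reason for this difference.

On these data alone, whether chloro, methoxy or an amine at this carbon would track bromo or hydrogen remains open. Also open, as far as these compounds go, is whether the bromo step would hold with the amide side chain of compound 3.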